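From two fluoro groups to fluoro and chloro

The source may hold more compounds than are shown below. What is called first, only, known or untested is meant among the compounds shown, and "the series" means these compounds.

Compound 1, `Clc1ccc(-c2nc3ncccc3o2)cc1`: in a functional assay on the whole organism for inhibition, with Rattus norvegicus as the target, at a dose of 30 mg/kg (on this read-out lower numbers stand for less inhibition and higher numbers for more inhibition at the one dose given (going by the name of the read-out)), compound 1 gives 24%.
Compound 2, `Fc1ccc(-c2nc3ncccc3o2)c(F)c1`: in this assay compound 2 gives 23%.

On paper compound 2 holds the lowest of the two numbers, yet compound 1 sits only a hair above it, within the scatter, so the two stand level. Compound 3, `Fc1cc(Cl)ccc1-c1nc2ncccc2o1`, has not been measured. It differs from compound 2 in one place: chloro in place of fluoro on an aromatic carbon. Among the measured compounds shown here, no step between measured compounds exists to guide the size of this change in this assay, and only a shift within the scatter is expected because compound 1 gives 24% while already carrying chloro. Compound 3 is estimated at 25%, with a range from 10% to 40%. The expected step of a number 2 percentage points higher from compound 2 to compound 3 (within the scatter) is therefore essentially none.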

Compound 3, a percentage reported as inhibition, in the whole organism at one dose (the size of the read-out at that dose, not a potency): 19%
Compound 3: the middle estimate sits 6 percentage points above what was measured; the measured number falls inside the stated range.
By their numbers in this assay, from the lowest: compounds 3, 2 and 1 (each within the scatter of the next).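

This position now has its first measured steps in this assay: chloro in place of fluoro on the aromatic carbon gives a number 4 percentage points lower from compound 2 to compound 3 (within the scatter) and fluoro in place of hydrogen on an aromatic carbon gives a number 5 percentage points lower from compound 1 to compound 3 (within the scatter) at the ring shared by these compounds. Neither halogen swap carries the read-out beyond the usual scatter, so the three compounds stand level. No measurement at hand explains this result.

Going by these compounds, whether an amine or a carboxylic acid at this position would shift the read-out beyond the scatter remains open. So does the effect of a longer chain there.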